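Butylamino removal from a tert-butyl quinone core

A few compounds are considered here, and "the series" means these few. Any claim that something is new, unique, unknown or untested is made for them only; others in the source may bear on it.

Compound 1 `CCCCNC1=CC(=O)C=C(C(C)(C)C)C1=O` gives 11000 nM in an ADME assay on HaCaT cells (Homo sapiens) for cytotoxicity, read by MTT assay, with a stated time of 72 h; on this read-out lower numbers stand for stronger inhibition and higher numbers for weaker inhibition.
Compound 2 `CCCCNC1=CC(=O)C(C(C)(C)C)=CC1=O` is reported only as a limit in this assay, > 100000 nM.

Two compounds share the core of compound 1, both carrying a butylamino group and a tert-butyl group, and they differ in where those groups sit. Compound 1 gives a measured number in this assay. Compound 2 stands at the limit of > 100000 nM in this assay, at which 1 of the 2 values shown sits, so nothing more than that limit is known of it; it is the one of the two whose value is not a number.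

Compound 3 `CC(C)(C)C1=CC(=O)C=CC1=O` has not been measured in this assay. It differs from compound 2 in one place: hydrogen in place of butylamino on a double-bonded ring carbon. Within the data shown here, no pair of measured compounds shows what this change does, so the size of the step cannot be drawn from the data at hand. The loss of the butylamino group leaves a smaller compound with only the tert-butyl group on the ring.

Compound 3 is expected to give about 30000 nM in this assay, within a range from 5000 nM to 200000 nM. The step this estimate means, an at least 3.3-fold lower number from compound 2 to compound 3 (0.52 log units; beyond the scatter), is an expectation toward a measurable number rather than another limit, but it is held loosely, since compound 2 offers no number to start from.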

Compound 3, half-maximal inhibitory concentration: 95000 nM
For compound 3 the middle estimate is 3.2-fold (0.50 log units) below the measured one, and the stated range covers the measured number.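

In this assay, an 8.6-fold higher number from compound 1 to compound 3 (0.94 log units; beyond the scatter) gives the first measured size for hydrogen in place of butylamino on a double-bonded ring carbon, and from this placement the loss of butylamino goes with weaker inhibition. Compound 2 gives only a limit and not a number: the limit of > 100000 nM in this assay, at which 1 of the 3 values shown sits. Read from that limit, the same change is an at least 1.0-fold lower number from compound 2 to compound 3 (0.02 log units; that floor lies within the scatter), so the two placements of butylamino do not run the same way on reaching the same product: the number rises from one and does not rise from the other, although the true size of the step from the limit remains unknown and only its floor can be read.

The compounds shown leave open how far the true value of compound 2 lies from its limit, and so how large the gap between the two placements really is. They also leave open whether a shorter chain such as ethylamino, a longer chain such as hexylamino, or a hydroxyl group on the same ring carbon would hold the number of compound 1 or move it toward that of compound 3.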